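A few compounds are considered here, and "the series" means these few. Any claim that something is new, unique, unknown or untested is made for them only; others in the source may bear on it.

Measured so far:
Compound 1 `COc1ccc(/C=C2\SC(=O)N(CCNC(=O)Nc3c(C)n(C)n(-c4ccccc4)c3=O)C2=O)cc1` gives 3160 nM
Compound 2 `Cc1c(NC(=O)NCCN2C(=O)S/C(=C\c3ccc([N+](=O)[O-])cc3)C2=O)c(=O)n(-c2ccccc2)n1C` gives 44800 nM

Both were read in a functional assay on HCT-116 cells (Homo sapiens) for inhibition, read by MTT assay, with a stated time of 48 h (on this read-out higher numbers stand for weaker inhibition and lower numbers for stronger inhibition), and compound 2 holds the higher number of the two. Compound 3 `COc1cc(/C=C2\SC(=O)N(CCNC(=O)Nc3c(C)n(C)n(-c4ccccc4)c3=O)C2=O)cc(OC)c1OC` differs from compound 2 by 3,4,5-trimethoxyphenyl in place of 4-nitrophenyl on a double-bonded chain carbon bound to a double-bonded ring carbon with 3,4,5-trimethoxyphenyl in place of 4-nitrophenyl on a double-bonded chain carbon bound to a double-bonded ring carbon. Within the data shown here, the one measured step bearing on this is a 14-fold higher number from compound 1 to compound 2 (1.15 log units; beyond the scatter) with nitro in place of methoxy on an aromatic carbon, large and beyond the scatter. Methoxy groups return here, so the expected step is a 13-fold lower number from compound 2 to compound 3 (1.11 log units; beyond the scatter) toward a lower number, of similar size, resting on that single pair. The estimated value for compound 3 is 3500 nM (expected range 1100 nM to 14000 nM).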

Compound 3, half-maximal inhibitory concentration: 12500 nM
The estimate for compound 3 lay 3.6-fold (0.55 log units) below the measured number; low and high end bracket the measured number.
By their numbers in this assay, from the lowest: compound 1; then compound 3; then compound 2.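

Putting 3,4,5-trimethoxyphenyl in place of 4-nitrophenyl brings (a 3.6-fold lower number from compound 2 to compound 3 (0.55 log units; beyond the scatter)), so inhibition gets stronger, but the gain is smaller than the one seen with 4-methoxyphenyl. Putting 3,4,5-trimethoxyphenyl in place of 4-methoxyphenyl gives (a 4.0-fold higher number from compound 1 to compound 3 (0.60 log units; beyond the scatter)), so among these three compounds, more methoxy groups do not mean stronger inhibition, and compound 1 remains the strongest. Nothing available explains this order.

As far as these compounds go, how an amine or a carboxylic acid would read at this position remains open, as does whether the order holds with a longer chain linking the core.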